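Ester chain variation and rat microsomal half-life

This account rests on a few compounds, and the source may have more. Where it says the series, first, only, none or still open, it means among the compounds named here.

Measured so far in an ADME assay (liver) for pharmacokinetics, with Liver microsome (Rattus norvegicus) as the target, using microsomes; on this read-out lower numbers stand for a shorter-lived compound and higher numbers for a longer-lived compound:
- compound 1 `CCCOC(=O)/C=C/c1ccc(NC(=O)C2(NC(=O)c3ccc4c(C5CCCC5)c(-c5ncc(Cl)cn5)n(C)c4c3)CCC2)cc1OCC`: 0.35 h
- compound 2 `CCOc1cc(NC(=O)C2(NC(=O)c3ccc4c(C5CCCC5)c(-c5ncc(Cl)cn5)n(C)c4c3)CCC2)ccc1/C=C/C(=O)OCC(C)C`: 1.42 h
- compound 3 `CCCCCCOC(=O)/C=C/c1ccc(NC(=O)C2(NC(=O)c3ccc4c(C5CCCC5)c(-c5ncc(Cl)cn5)n(C)c4c3)CCC2)cc1OCC`: 12.7 h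

Compound 3 has the highest number of the three; compound 2 is the nearest to it and compound 1 the furthest, both gaps beyond the scatter. All three measured steps run in the same direction: a 4.1-fold higher number from compound 1 to compound 2 (0.61 log units; beyond the scatter), an 8.9-fold higher number from compound 2 to compound 3 (0.95 log units; beyond the scatter), and a 36-fold higher number from compound 1 to compound 3 (1.56 log units; beyond the scatter). Each enlarges the group on the ester oxygen, and each raises the half-life.

Compound 4 `CCOc1cc(NC(=O)C2(NC(=O)c3ccc4c(C5CCCC5)c(-c5ncc(Cl)cn5)n(C)c4c3)CCC2)ccc1/C=C/C(=O)OCCOc1ccccc1` is not yet measured. Its change from compound 3 is phenoxy in place of butyl on a saturated chain carbon, two bonds along the chain from an oxygen next to a carbonyl group. Among the measured compounds shown here, none of the measured steps contains a ring or an ether oxygen in the ester group, so none bears on this change directly. What the measured steps do show is that, within this set, a larger ester group went with a longer half-life; compound 4 keeps a group of comparable size but replaces part of the chain with an aromatic ring and an oxygen. The expectation is therefore a number near that of compound 3, with wide uncertainty, the expected step being a 2.1-fold lower number from compound 3 to compound 4 (0.33 log units; beyond the scatter). Compound 4 is estimated at 6 h, in the range 1.5 h to 25 h.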

Compound 4, half-life: 16.5 h
Estimate against measurement, compound 4: 2.8-fold (0.44 log units) below; low and high end bracket the measured number.
By their numbers in this assay, from the lowest: compound 1; then compound 2; then compounds 3 and 4 (each within the scatter of the next).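

In this assay, phenoxy in place of butyl on a saturated chain carbon, two bonds along the chain from an oxygen next to a carbonyl group, gives a 1.3-fold higher number from compound 3 to compound 4 (0.11 log units; within the scatter) and so places an ester group with a six-membered aromatic ring and an ether oxygen level with the hexyl ester. The link between a larger ester group and a longer half-life therefore stops at this step, where the heavy-atom count of the entering group exceeds that of the leaving group with no change beyond the scatter, although the same group still gives a 12-fold higher number from compound 2 to compound 4 (1.07 log units; beyond the scatter) and a 47-fold higher number from compound 1 to compound 4 (1.67 log units; beyond the scatter) against the two smaller ester groups. Nothing at hand explains these numbers.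

The compounds shown leave open whether the aromatic ring or the ether oxygen carries the result, a question a 3-phenylpropyl ester would separate, and whether an octyl chain would read any differently from hexyl. They also leave open how the carboxylic acid or an amide in place of the ester would read on this half-life.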